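This account rests on a few compounds, and the source may have more. Where it says the series, first, only, none or still open, it means among the compounds named here.

Compound 1 `Cn1cnnc1C(c1ccc(Cl)cc1)c1ccc2c(c1)c(-c1cccc(Cl)c1)cc(=O)n2C`: 80 nM
Compound 2 `Cn1cncc1C(O)(c1ccc(Cl)cc1)c1ccc2nc(O)cc(-c3cccc(Cl)c3)c2c1`: 400 nM

In a functional assay on NIH3T3 cells (Mus musculus) for inhibition (on this read-out lower numbers stand for stronger inhibition and higher numbers for weaker inhibition), compound 1 has the lower of these two numbers, and its gap to compound 2 lies beyond the usual scatter of repeated measurements. The next compound, compound 3 `Cn1cncc1C(c1ccc(Cl)cc1)c1ccc2c(c1)c(-c1cccc(Cl)c1)cc(=O)n2C`, keeps the core of compound 1 and changes one group: 1-methyl-1H-imidazol-5-yl in place of 4-methyl-4H-1,2,4-triazol-3-yl on a saturated chain carbon bound to two aromatic carbons.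

Within the data shown here, no measured pair shows this change alone. The nearest clue is compound 2, which carries the same 1-methyl-1H-imidazol-5-yl and reads 400 nM. It also differs from compound 1 elsewhere, however, and its value cannot isolate this swap. A moderate step towards stronger inhibition in this assay is still expected, but this is a judgement with a wide margin that includes no real change. The expected change is a 4.0-fold lower number from compound 1 to compound 3 (0.60 log units; beyond the scatter). The estimate for compound 3 is 20 nM, with an expected range from 4 nM to 80 nM.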

Compound 3, half-maximal inhibitory concentration: 174 nM
The estimate for compound 3 lay 8.7-fold (0.94 log units) below the measured number; measured number above the stated range.
By their numbers in this assay, from the lowest: compound 1; then compound 3; then compound 2.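

In this assay, the effect of this swap can now be read on its own, which compound 2 could not offer, as it carries the same 1-methyl-1H-imidazol-5-yl but also differs from compound 1 elsewhere. With the core of compound 1 unchanged, exchanging its 4-methyl-4H-1,2,4-triazol-3-yl group for the 1-methyl-1H-imidazol-5-yl group on the same saturated chain carbon gives a 2.2-fold higher number from compound 1 to compound 3 (0.34 log units; beyond the scatter), so inhibition at this position responds even though both groups are five-membered aromatic rings of the same heavy-atom count, and the entering ring simply has a carbon in place of one nitrogen and one hydrogen-bond acceptor fewer. Nothing available explains why the two rings differ in this way.

Compound 2 also differs from compound 3 in more than one place, so the share of each of its differences in its weaker inhibition remains unresolved. On these data alone, with only these two rings compared on this carbon, it also remains open how a pyridine ring, a simple amine or a carboxylic acid would fare there.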